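Varying the sulfur-bound chain on the shared core

A few compounds are considered here, and "the series" means these few. Any claim that something is new, unique, unknown or untested is made for them only; others in the source may bear on it.

Compound 1 `Cc1ccc(-c2nc(NO)c3cc(Cl)ccc3n2)cc1` gives 6.81 ug/mL in a functional assay on MCF7 cells (Homo sapiens) for antiproliferative activity, read by MTT assay, with a stated time of 48 h; a higher number here means a weaker inhibitor, a lower number a stronger inhibitor. Compound 2 `CSc1nc(-c2ccc(C)cc2)nc2ccc(Cl)cc12` gives 8.64 ug/mL, and compound 3 `C=CCSc1nc(-c2ccc(C)cc2)nc2ccc(Cl)cc12` gives 8.03 ug/mL. Compound 3 stands within the scatter of both others: nearest is a 1.1-fold lower number from compound 2 to compound 3 (0.03 log units; within the scatter), furthest is a 1.2-fold higher number from compound 1 to compound 3 (0.07 log units; within the scatter). Compound 4 `Cc1ccc(-c2nc(SCCO)c3cc(Cl)ccc3n2)cc1` differs from compound 3 by hydroxymethyl in place of vinyl on a saturated chain carbon bound to a sulfur. Among the measured compounds shown here, the one measured step on this same carbon, a 1.1-fold lower number from compound 2 to compound 3 (0.03 log units; within the scatter), lies within the scatter, as do a 1.3-fold higher number from compound 1 to compound 2 (0.10 log units; within the scatter) and a 1.2-fold higher number from compound 1 to compound 3 (0.07 log units; within the scatter); none of the three exchanges at this position has moved the number. In this assay no step beyond the scatter is therefore expected, a 1.0-fold lower number from compound 3 to compound 4 (0.00 log units; within the scatter). For compound 4 the estimate is 8 ug/mL, with a range from 4.5 ug/mL to 14 ug/mL.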

Compound 4, half-maximal inhibitory concentration: 3.76 ug/mL
Estimate against measurement, compound 4: 2.1-fold (0.33 log units) above; measured number below the stated range.
By their numbers in this assay, from the lowest: compounds 4, 1, 3 and 2 (each within the scatter of the next, the first and the last beyond it).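

Only now does the sulfur-bound chain move the number in this assay: hydroxymethyl in place of vinyl gives a 2.1-fold lower number from compound 3 to compound 4 (0.33 log units; beyond the scatter) and hydroxymethyl in place of hydrogen gives a 2.3-fold lower number from compound 2 to compound 4 (0.36 log units; beyond the scatter) on the same saturated chain carbon. The (2-hydroxyethyl)sulfanyl exchange for hydroxyamino on the aromatic carbon stays smaller, at a 1.8-fold lower number from compound 1 to compound 4 (0.26 log units; within the scatter) and so within the scatter.

From the compounds shown here alone, whether the hydroxyl itself carries these steps stays open, and a methoxy or amine end on this chain, or a longer hydroxyalkyl chain, would bear on that. Nothing available accounts for the steps.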